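The source may report more compounds than this note shows. Statements on the series, on what has been measured and on what is new or still open speak of the compounds shown alone.

Measured in a physicochemical assay for acid dissociation:
- compound 1 `CC(C)=CCN(C1=NCCN1)c1c(Br)cccc1Br`: 10.8
- compound 2 `C=C(C)CCN(C1=NCCN1)c1c(Br)cccc1Br`: 10.9
- compound 3 `Brc1cccc(Br)c1N(CC1CCC1)C1=NCCN1`: 10.9

Compound 3 stands level with compound 2 at the digits shown, and all three values lie within the scatter of one another. The next compound to be measured in this assay is compound 4 `Brc1cccc(Br)c1N(C1=NCCN1)C1CCCC1`, with cyclopentyl in place of cyclobutylmethyl on a nitrogen on an aromatic ring.

Within the data shown here, three measured steps bear on this change, and each is small: a number 0.10 log units higher from compound 1 to compound 2 (within the scatter), a number 0.10 log units higher from compound 1 to compound 3 (within the scatter) and no change at the digits printed from compound 2 to compound 3 (within the scatter). None of them is the exchange made here. All three alter a group on a saturated chain carbon bound to a nitrogen on an aromatic ring, whereas the new change sits on that nitrogen itself, so they are only indirect evidence. Among the measured compounds shown here, the series holds no measured example of cyclopentyl in this place.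

With that caution, the flat run of values, with compound 3 giving 10.9, supports no expectation of a real move in either direction. The estimated change is no change at the digits printed from compound 3 to compound 4 (within the scatter), which means no step beyond the scatter is expected. The expected value for compound 4 is 10.9, with an estimated range of 10.5 to 11.3.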

Compound 4, acid dissociation constant: 11.2
Estimate against measurement, compound 4: 0.30 log units below; the measured number falls inside the stated range.
By their numbers in this assay, from the lowest: compounds 1, 2, 3 and 4 (each within the scatter of the next, the first and the last beyond it).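

In this assay, among these compounds, cyclopentyl on a nitrogen on an aromatic ring gives the first step beyond the scatter, a number 0.40 log units higher from compound 1 to compound 4 (beyond the scatter) when it replaces 3-methylbut-2-en-1-yl, though that step is only modest. The same group does not separate from the other two, with a number 0.30 log units higher from compound 2 to compound 4 (within the scatter) when it replaces 3-methylbut-3-en-1-yl and a number 0.30 log units higher from compound 3 to compound 4 (within the scatter) when it replaces cyclobutylmethyl, an exchange that keeps the same atoms joined differently. This position therefore now shows one pair of compounds set apart in a series that had been flat, but nothing measured here bears on the reason for it.

The exchange of cyclobutylmethyl for cyclopentyl alters both the ring size and the way the ring is joined, so a group such as cyclopentylmethyl on this nitrogen would be needed to tell the two apart. Also open is how this assay would read with a group carrying a heteroatom in this place, such as an amine or a carboxylic acid on a longer chain, since every group shown here is carbon only.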